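Aryl Exchange on the Carbonyl Carbon: Compound 2 to Compound 3

The compounds below may be only part of what the source reports. "The series", "measured", "known", "first", "only" and "open" are said of these compounds alone.

Measured so far in a functional assay on A549 cells (Homo sapiens) for antiproliferative activity, read by MTT assay, with a stated time of 24 h; on this read-out lower numbers stand for stronger inhibition and higher numbers for weaker inhibition:
Compound 1 `COc1cc(-c2cc(/C=C/C(=O)c3ccc(C)c(C)c3)nc3cc(-c4ccccc4)nn23)cc(OC)c1OC` gives 10600 nM.
Compound 2 `COc1ccc(C(=O)/C=C/c2cc(-c3cc(OC)c(OC)c(OC)c3)n3nc(-c4ccccc4)cc3n2)cc1OC` gives 17800 nM.

Compound 2 holds the highest of these two numbers; its nearest neighbour is compound 1, and the step of a 1.7-fold higher number from compound 1 to compound 2 (0.23 log units; within the scatter) is within the scatter. Compound 3 `COc1cc(-c2cc(/C=C/C(=O)c3ccc(Cl)cc3)nc3cc(-c4ccccc4)nn23)cc(OC)c1OC` differs from compound 2 by 4-chlorophenyl in place of 3,4-dimethoxyphenyl on a carbonyl carbon. Within the data shown here, the only measured step, a 1.7-fold higher number from compound 1 to compound 2 (0.23 log units; within the scatter), also exchanged the aryl group on the carbonyl carbon and moved the number by less than the scatter, so no step beyond the scatter is expected in this assay for compound 3 either. On that basis compound 3 is estimated at 13000 nM, with a range from 5000 nM to 35000 nM, an expected step of a 1.4-fold lower number from compound 2 to compound 3 (0.14 log units; within the scatter).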

Compound 3, half-maximal inhibitory concentration: 15500 nM
Compound 3: the middle estimate sits 1.2-fold (0.08 log units) below what was measured, within the range that was stated.
By their numbers in this assay, from the lowest: compounds 1, 3 and 2 (each within the scatter of the next).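

A chlorine-bearing aryl group on the carbonyl carbon now joins the dimethyl and dimethoxy ones, and both new steps, a 1.1-fold lower number from compound 2 to compound 3 (0.06 log units; within the scatter) and a 1.5-fold higher number from compound 1 to compound 3 (0.17 log units; within the scatter), lie within the scatter in this assay. Across these three aryl groups, then, the exchange at this position does not separate the compounds. No evidence is available on what lies behind this result.

Going by these compounds, whether an amine or a carboxylic acid on this aryl ring, or a longer chain in its place, would move the number beyond the scatter remains open.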